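The source may hold more compounds than are shown below. What is called first, only, known or untested is meant among the compounds shown, and "the series" means these compounds.

Compound 1 `COc1ccc(F)cc1CNCCCNc1ccnc2cc(Cc3cc(C)cc(C)c3)ccc12` sits at the low end of the three numbers in hand. In a physicochemical assay for solubility, with a stated time of 18 h, at pH 7.4 (a higher number here means a more soluble compound, a lower number a less soluble compound), compound 1 gives 4200 nM, and compound 3 `Cc1cc(C)cc(Cc2ccc3c(NCCCNCc4ccco4)ccnc3c2)c1` gives 4200 nM, so the two stand level; the step of no change at the digits printed from compound 1 to compound 3 (within the scatter) confirms this. Compound 2 `COc1cccc(CNCCCNc2ccnc3cc(Oc4ccc(F)cc4)ccc23)c1O` stands apart from both, as compound 2 gives 14500 nM in this assay.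

Compound 4 `COc1ccc(F)cc1CNCCCNc1ccnc2cc(Cc3ccc(C#N)cc3)ccc12` is reached from compound 1 by the change (4-cyanophenyl in place of 3,5-dimethylphenyl on a saturated chain carbon bound to an aromatic carbon). Within the data shown here, none of the measured steps touches this part of the molecule: the one step available, no change at the digits printed from compound 1 to compound 3 (within the scatter), concerns the group on the saturated chain carbon bound to an amine nitrogen, and compound 2 differs from compound 1 in more than one place, so only their two values can be set side by side. The 4-cyanophenyl group brings one hydrogen-bond acceptor where 3,5-dimethylphenyl brought none, and on that basis a modest rise is expected rather than none. Compound 4 is therefore estimated at 8000 nM in this assay, within 3000 nM to 25000 nM, which means an expected step of a 1.9-fold higher number from compound 1 to compound 4 (0.28 log units; within the scatter).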

Compound 4, solubility: 4200 nM
Beside the measured number, compound 4's estimate is 1.9-fold (0.28 log units) above it; measured number inside the range.
By their numbers in this assay, from the lowest: compounds 1, 3 and 4 (each within the scatter of the next); then compound 2.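

At the saturated chain carbon bound to an aromatic carbon, this assay now gives a first reading, with 4-cyanophenyl in place of 3,5-dimethylphenyl: no change at the digits printed from compound 1 to compound 4 (within the scatter). Here a group with 1 hydrogen-bond acceptor replaces one with 0, and this one pair shows no link between that count and the read-out, which also means that neither of the two places changed from compound 1 so far has shifted the number beyond the scatter. Nothing measured here accounts for this result.

Open, from the compounds shown here alone, is whether a carboxylic acid or a morpholine on the benzyl group would move the number beyond the scatter. Also open, going by these compounds, is whether the same change would read alike with the furan-2-yl group of compound 3 in place of 5-fluoro-2-methoxyphenyl.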